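Extending the fluorinated chain on compound 3: an estimate

A few compounds are considered here, and "the series" means these few. Any claim that something is new, unique, unknown or untested is made for them only; others in the source may bear on it.

Compound 1 `O=c1c2c(C(F)(F)F)cc(-c3ccccc3)nc2ncn1Cc1cn(CCC(F)(F)C(F)(F)C(F)(F)C(F)(F)C(F)(F)C(F)(F)C(F)(F)C(F)(F)F)nn1`: 79.1 ug/mL
Compound 2 `Cc1nc2nc(-c3ccccc3)cc(C(F)(F)F)c2c(=O)n1Cc1cn(CCC(F)(F)C(F)(F)C(F)(F)C(F)(F)C(F)(F)C(F)(F)C(F)(F)C(F)(F)F)nn1`: > 200 ug/mL
Compound 3 `CCc1nc2nc(-c3ccccc3)cc(C(F)(F)F)c2c(=O)n1Cc1cn(CCC(F)(F)C(F)(F)C(F)(F)C(F)(F)C(F)(F)C(F)(F)F)nn1`: > 200 ug/mL

In a functional assay on THP-1 cells (Homo sapiens) for cytotoxicity, read by MTT assay, with a stated time of 24 h (on this read-out lower numbers stand for stronger inhibition and higher numbers for weaker inhibition), compound 1 gives 79.1 ug/mL. For compound 2 the read-out is a limit of the assay, > 200 ug/mL. For compound 3 the read-out is likewise a limit, > 200 ug/mL; compound 3 therefore stands among the two values that sit at the limit of > 200 ug/mL in this assay, at which 2 of the 3 values shown sit, and no number is known for it.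

Compound 4 `CCc1nc2nc(-c3ccccc3)cc(C(F)(F)F)c2c(=O)n1Cc1cn(CCC(F)(F)C(F)(F)C(F)(F)C(F)(F)C(F)(F)C(F)(F)C(F)(F)C(F)(F)F)nn1` differs from compound 3 in one place: 1,1,2,2,2-pentafluoroethyl in place of fluoro on a saturated chain carbon bound to two fluorine atoms and a saturated chain carbon. For the measured compounds named here, the only measured step, an at least 2.5-fold higher number from compound 1 to compound 2 (0.40 log units; beyond the scatter), concerns the methyl group on the shared core and does not touch the fluorinated chain, so no measured step bears directly on the change from compound 3 to compound 4. Compound 2, which carries the longer fluorinated chain, and compound 3, which carries the shorter one, both return a limit in this assay, though they also differ in the group on the core.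

With both neighbours at the limit, compound 4 is expected to stay near the limit as well, with a step that the limit leaves unreadable from compound 3 to compound 4. The estimate for compound 4 is 250 ug/mL, within a range from 110 ug/mL to 600 ug/mL.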

Compound 4, half-maximal inhibitory concentration: > 200 ug/mL
Compound 4 was reported as a limit; the forecaster's own chance of this, stated with the estimate: 75%; the middle value lies beyond the limit too.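

In this assay, compound 4 gives a limit, > 200 ug/mL, and not a number. The steps joining it to compound 2 and compound 3 cannot be read, so 1,1,2,2,2-pentafluoroethyl in place of fluoro on a saturated chain carbon bound to two fluorine atoms and a saturated chain carbon has no measurable size here, and the same holds for methyl in place of hydrogen on a saturated chain carbon bound to an aromatic carbon. The one readable new step is an at least 2.5-fold higher number from compound 1 to compound 4 (0.40 log units; beyond the scatter), for the change to ethyl on the aromatic carbon; it runs in the same direction as the methyl change, an at least 2.5-fold higher number from compound 1 to compound 2 (0.40 log units; beyond the scatter), and the values now gather at one end of the assay: the limit of > 200 ug/mL in this assay, at which 3 of the 4 values shown sit.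

Among the compounds shown, only compound 1 gives a number, 79.1 ug/mL, so the effect of chain length on this read-out stays open. Also open, as far as these compounds go, is whether an amine on that aromatic carbon, or a shorter fluorinated chain on the core of compound 1, would give a measured value.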